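The source may hold more compounds than are shown below. What is called first, only, known or untested is meant among the compounds shown, and "the series" means these compounds.

Measured compounds:
- compound 1 `CC(=O)C1CCC(Cn2c(-c3ccc(OCc4c(-c5c(Cl)cccc5Cl)noc4C(C)C)cc3)nc3ccc(C(=O)O)cc32)CC1`: "not determined" (no result reported)
- compound 2 `CC(C)Cn1c(-c2ccc(OCc3c(-c4c(Cl)cccc4Cl)noc3C(C)C)cc2)nc2ccc(C(=O)O)cc21`: 24.7 nM

For the measured compounds named here, in an assay on isolated protein for agonist activity at Bile acid receptor (Homo sapiens), read by TR-FRET (a higher number here means that more compound is needed for the effect, a lower number that less compound is needed), compound 2 gives 24.7 nM and is the only compound of the series with a number; compound 1 carries no value, so no step between measured compounds is available. Compound 3 `CCCC(CCC)n1c(-c2ccc(OCc3c(-c4c(Cl)cccc4Cl)noc3C(C)C)cc2)nc2ccc(C(=O)O)cc21` differs from compound 2 by 1-propylbutyl in place of isobutyl on an aromatic nitrogen. With nothing measured to anchor this change, the step from compound 2 to compound 3 is expected to stay within the usual scatter, a 1.2-fold higher number from compound 2 to compound 3 (0.08 log units; within the scatter). For compound 3 in this assay the estimate is 30 nM, with a range from 8 nM to 120 nM.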

Compound 3, half-maximal effective concentration: 30.3 nM
The estimate for compound 3 lay 1.0-fold (0.00 log units) below the measured number; low and high end bracket the measured number.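

In this assay, for the compounds shown here, the first readable step at this aromatic nitrogen is a 1.2-fold higher number from compound 2 to compound 3 (0.09 log units; within the scatter), for 1-propylbutyl in place of isobutyl. Both groups are purely carbon and without a ring, so going from 4 to 7 heavy atoms here leaves the number within the scatter. No supporting data bear on why this step is so small.

As far as these compounds go, whether this holds for a group carrying an amine or a hydroxyl on this nitrogen stays open. From the compounds shown here alone, a chain much longer than 1-propylbutyl is equally open.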